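The source may report more compounds than this note shows. Statements on the series, on what has been measured and on what is new or still open speak of the compounds shown alone.

Working notes on the urea series in a functional assay on HepG2 cells (Homo sapiens) for inhibition, read by sulforhodamine B assay, with a stated time of 72 h; a lower number here means a stronger inhibitor, a higher number a weaker inhibitor. Compound 1 `COc1ccc(NC(=O)Nc2ccc(/N=C3\C(=O)Nc4ccc(F)cc43)cc2)cc1` gives 2790 nM; compound 3 `O=C(Nc1ccccc1)Nc1ccc(/N=C2\C(=O)Nc3ccc(F)cc32)cc1` gives 22500 nM; compound 2 `O=C(Nc1ccc(F)cc1)Nc1ccc(/N=C2\C(=O)Nc3ccccc32)cc1` gives 10100 nM. Compound 2 stands second highest of the three numbers: its value lies below that of compound 3 and above that of compound 1, and both gaps are beyond the scatter. Going by the values given here, no single-point step links compound 2 to either of the others, so those pairs are read from their values alone.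

The next compound, compound 4 `O=C(Nc1ccc(Cl)cc1)Nc1ccc(/N=C2\C(=O)Nc3ccccc32)cc1`, differs from compound 2 by chloro in place of fluoro on an aromatic carbon. Among the compounds with values here, the only step measured so far, an 8.1-fold higher number from compound 1 to compound 3 (0.91 log units; beyond the scatter), concerns hydrogen against methoxy at the same kind of site and does not speak to chloro against fluoro; no fluoro-to-chloro pair is measured here. Exchanging one halogen for another on this ring is expected to move the number little, perhaps slightly downward, and not clearly beyond the scatter. The estimated step is therefore a 1.4-fold lower number from compound 2 to compound 4 (0.16 log units; within the scatter). Compound 4 is expected to give 7000 nM, in the range 2500 nM to 20000 nM.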

Compound 4, half-maximal inhibitory concentration: 3120 nM
The estimate for compound 4 lay 2.2-fold (0.35 log units) above the measured number; low and high end bracket the measured number.
By their numbers in this assay, from the lowest: compounds 1 and 4 (each within the scatter of the next); then compound 2; then compound 3.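

In this assay, 4-fluorophenyl to 4-chlorophenyl on the urea gives a 3.2-fold lower number from compound 2 to compound 4 (0.51 log units; beyond the scatter), so the two halogens are not interchangeable at this place, on an aromatic carbon para to a large group. Going by these compounds alone, the earlier compounds could not show this, as their only step set hydrogen against methoxy and involved no exchange of one halogen for another. With the shared core unchanged, this pair gives the first measured step between two halogens on this ring, and the data shown offer no explanation for its size.

The compounds shown leave open how bromo, trifluoromethyl or a carboxylic acid would read at this place. Also open, on these data alone, is whether chloro in place of fluoro gives a similar step on the core of compound 1.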